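From Cyclopentyl to 4-Nitrophenyl on the Amine Arm

The compounds below may be only part of what the source reports. "The series", "measured", "known", "first", "only" and "open" are said of these compounds alone.

Of the compounds shown here, three sharing one core have been tested in a functional assay on the whole organism for antagonist activity, with Mus musculus as the target; on this read-out higher numbers stand for an effect only at larger amounts of compound and lower numbers for an effect already at smaller amounts. Compound 1, `COc1cc(N)c(Cl)cc1NC(=O)C1CCN(CC2CCCCC2)CC1`, gives 2.9 mg/kg. Compound 2, `COc1cc(N)c(Cl)cc1NC(=O)C1CCN(CC2CCCCCC2)CC1`, reaches only the limit of the assay, reported as > 10 mg/kg. Compound 3, `COc1cc(N)c(Cl)cc1NC(=O)C1CCN(CC2CCCC2)CC1`, likewise sits at the limit, reported as > 10 mg/kg. Compound 3 therefore stands among the limit values, where two of the three results are limits rather than numbers (the limit of > 10 mg/kg in this assay, at which 2 of the 3 values shown sit). The steps of an at least 3.4-fold higher number from compound 1 to compound 2 (0.53 log units; beyond the scatter) and an at least 3.4-fold higher number from compound 1 to compound 3 (0.53 log units; beyond the scatter) show that a cycloheptyl or a cyclopentyl group in place of cyclohexyl gives a higher number, while the step that the two limits leave unreadable from compound 2 to compound 3 cannot be read.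

Compound 4, `COc1cc(N)c(Cl)cc1NC(=O)C1CCN(Cc2ccc([N+](=O)[O-])cc2)CC1`, differs from compound 3 as follows: 4-nitrophenyl in place of cyclopentyl on a saturated chain carbon bound to an amine nitrogen in a ring. Among the measured compounds shown here, no measured step involves an aromatic group at this position, so the measured steps fix only the starting point: compound 3 sits at a limit, and any real number for compound 4 would mean a lower value. The ring-size steps give no guide to an aromatic ring bearing a nitro group. Compound 4 is expected to fall near 5 mg/kg, within 1.5 mg/kg to 15 mg/kg. That estimate means the step of an at least 2.0-fold lower number from compound 3 to compound 4 (0.30 log units; that floor lies within the scatter) is expected, with considerable uncertainty and a fair chance that the assay again returns only a limit.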

Compound 4, dose for half-maximal effect: > 4 mg/kg
Compound 4 was reported as a limit (the forecaster's own chance of this, stated with the estimate: 40%); the middle value lies beyond the limit too.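

Compound 4 brings an aromatic ring to this position for the first time among the compounds shown, and in this assay compound 4 gives > 4 mg/kg, which is a limit of the assay and not a number. Against cyclohexyl the change gives an at least 1.3-fold higher number from compound 1 to compound 4 (0.13 log units; that floor lies within the scatter), so the 4-nitrophenyl group is not shown to match cyclohexyl, nor to fall short of it beyond the scatter. The steps to compound 2 and compound 3 cannot be read, so 4-nitrophenyl cannot be ranked against cycloheptyl or cyclopentyl, and compound 1 remains the only compound here with a true number, the rest being limits: the limit of > 10 mg/kg in this assay, at which 2 of the 4 values shown sit.

Going by these compounds, it remains open whether the aromatic ring or its nitro group sets the result, a question that a plain phenyl or a 4-aminophenyl on the same saturated chain carbon would help to separate. On these data alone, it also remains open where the real value of compound 4 lies relative to that of compound 1, and whether any aromatic ring at this place can equal cyclohexyl.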